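Benzylselanyl to methylsulfanyl on the amidine-type carbon

This account rests on a few compounds, and the source may have more. Where it says the series, first, only, none or still open, it means among the compounds named here.

Compound 1 `O=C(/N=C(/NC(=O)c1cc(-c2ccccc2)nc2ccccc12)[Se]Cc1ccccc1)c1cc(-c2ccccc2)nc2ccccc12` gives 97000 nM in a functional assay on MCF7 cells (Homo sapiens) for cytotoxicity, read by MTT assay, with a stated time of 72 h; a lower number here means that less compound is tolerated, a higher number that more compound is tolerated. Compound 2 `O=C(/N=C(/NC(=O)c1cccs1)[Se]Cc1ccccc1)c1cccs1` in this assay shows only a limit, > 100000 nM. Compound 3 `CS/C(=N\C(=O)c1cccs1)NC(=O)c1cccs1` in this assay likewise shows only a limit, > 100000 nM. The difference between the core of compound 1 and the core of compound 2 is not broken down here. From compound 2 to compound 3 the change is a group of 2 heavy atoms (1 carbon, 1 sulfur; no ring) in place of a group of 8 heavy atoms (7 carbon, 1 selenium; one six-membered aromatic ring of carbon only), on a carbon with a double bond to nitrogen, and the step that the two limits leave unreadable from compound 2 to compound 3 is unreadable because of the limit of > 100000 nM in this assay, at which 2 of the 3 values shown sit. Compound 4 `CS/C(=N\C(=O)c1cc(-c2ccccc2)nc2ccccc12)NC(=O)c1cc(-c2ccccc2)nc2ccccc12` is not yet measured; from compound 1 it differs by the same change, (a group of 2 heavy atoms (1 carbon, 1 sulfur; no ring) in place of a group of 8 heavy atoms (7 carbon, 1 selenium; one six-membered aromatic ring of carbon only), on a carbon with a double bond to nitrogen). Since compound 1 already sits at 97000 nM, the step of a 1.5-fold higher number from compound 1 to compound 4 (0.19 log units; within the scatter) is expected to be small. For compound 4 the estimate in this assay is 150000 nM, ranging from 60000 nM to 400000 nM.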

Compound 4, concentration lethal to 50% of the cells: > 100000 nM
Compound 4 gave a limit, no number; the forecaster's own chance of this, stated with the estimate: 70%; the middle value is on the limit's open side.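

In this assay compound 4 gives only a limit, > 100000 nM. Methylsulfanyl in place of the benzylselanyl group on the carbon with a double bond to nitrogen gives an at least 1.0-fold higher number from compound 1 to compound 4 (0.01 log units; that floor lies within the scatter); this is only a floor, so the true size of the change on the core of compound 1 remains unknown. Whether the change behaves alike on both cores cannot be said, since the step on the other core cannot be read and the two steps cannot be compared: the limit of > 100000 nM in this assay, at which 3 of the 4 values shown sit.

Going by these compounds, whether an aminoethyl or a carboxymethyl group on that same carbon would give a number rather than a limit remains open. Also open, on these data alone, is what replacing the selenium alone, with the benzyl group kept, would do.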